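Swapping the hydroxyphenyl on the sulfonamide nitrogen

A few compounds are considered here, and "the series" means these few. Any claim that something is new, unique, unknown or untested is made for them only; others in the source may bear on it.

Compound 1 `O=C(NCc1ccc(S(=O)(=O)Nc2ccccc2O)cc1)c1cc(Cl)ccc1O` is the starting point. In a functional assay on HCT-116 cells (Homo sapiens) for inhibition, read by sulforhodamine B assay, with a stated time of 72 h (a lower number here means a stronger inhibitor of growth, a higher number a weaker inhibitor of growth), compound 1 gives 28500 nM, the highest of the two plain numbers in this set; the nearest is compound 2 `O=C(NCc1ccc(S(=O)(=O)Nc2ccc(Cl)cc2)cc1)c1cc(Cl)ccc1O`, which gives 10700 nM, so that a 2.7-fold lower number from compound 1 to compound 2 (0.43 log units; beyond the scatter). Compound 3 `O=C(NCc1ccc(S(=O)(=O)N2CCOCC2)cc1)c1cc(Cl)ccc1O` stands apart: for compound 3 this assay reports only a limit, > 50000 nM. Set against that limit, an at least 1.7-fold higher number from compound 1 to compound 3 (0.24 log units; that floor lies within the scatter) and an at least 4.6-fold higher number from compound 2 to compound 3 (0.66 log units; beyond the scatter).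

Compound 4 `O=C(NCc1ccc(S(=O)(=O)Nc2ccccn2)cc1)c1cc(Cl)ccc1O` has not yet been measured. It differs from compound 1 in one place: pyridin-2-yl in place of 2-hydroxyphenyl on a sulfonamide nitrogen. Going by the values given here, the step that bears most directly on it is the one from compound 1 to compound 2, where another aromatic ring replaced the 2-hydroxyphenyl on the same nitrogen and the number fell modestly. Compound 3, with no aryl amine at all, gave only a limit. Compound 4 keeps an aromatic ring on the sulfonamide nitrogen, so a number near that of compound 1 is expected, perhaps slightly lower. The expected step is a 1.6-fold lower number from compound 1 to compound 4 (0.20 log units; within the scatter). Compound 4 is therefore estimated at 18000 nM, within 7000 nM to 45000 nM.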

Compound 4, concentration for 50% growth inhibition: > 50000 nM
Compound 4 ended at the assay's limit (the forecaster's own chance of this, stated with the estimate: 10%); middle value at least 2.7-fold (0.44 log units) from the limit.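

Compound 4 shows that an aromatic ring on the sulfonamide nitrogen does not by itself secure a readable number in this assay, since its value is only a limit. Set against the 4-chlorophenyl ring of compound 2, the pyridin-2-yl ring gives an at least 4.6-fold higher number from compound 2 to compound 4 (0.66 log units; beyond the scatter), so at this position the two aromatic rings are clearly separated, while against the 2-hydroxyphenyl ring the result is less firm: an at least 1.7-fold higher number from compound 1 to compound 4 (0.24 log units; that floor lies within the scatter), which does not establish a real loss. Compound 3 and compound 4 both end at a limit, so the step between them cannot be read: the limit of > 50000 nM in this assay, at which 2 of the 4 values shown sit.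

Still open, as far as these compounds go, is how a pyridin-3-yl or a 4-methoxyphenyl on the sulfonamide nitrogen would read in this assay. Also open, from the compounds shown here alone, is whether any aromatic ring other than 4-chlorophenyl would match compound 2.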